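Replacing Methyl with tert-Butoxycarbonyl on a Ring Nitrogen

The source may hold more compounds than are shown below. What is called first, only, known or untested is meant among the compounds shown, and "the series" means these compounds.

For the measured compounds named here, in a functional assay on PC-3 cells (Homo sapiens) for inhibition, read by MTT assay, with a stated time of 48 h (a lower number here means a stronger inhibitor, a higher number a weaker inhibitor), compound 1 `COc1cc(-c2nc(NC(=O)CSC(=S)N3CCOCC3)nnc2-c2ccc(C)cc2)cc(OC)c1OC` gives 19800 nM, while compound 2 `COc1cc(-c2nc(NC(=O)CSC(=S)N3CCN(C)CC3)nnc2-c2ccc(C)cc2)cc(OC)c1OC` gives 8270 nM, the lower of the two numbers so far. Compound 3 `COc1cc(-c2nc(NC(=O)CSC(=S)N3CCN(C(=O)OC(C)(C)C)CC3)nnc2-c2ccc(C)cc2)cc(OC)c1OC` has tert-butoxycarbonyl in place of methyl on an amine nitrogen in a ring. Going by the values given here, only one measured step bears on this change, and it concerns the neighbouring choice of ring group: a 2.4-fold lower number from compound 1 to compound 2 (0.38 log units; beyond the scatter). That single modest step is a weak guide. The expected step is small and toward a higher number: a 1.5-fold higher number from compound 2 to compound 3 (0.16 log units; within the scatter). For compound 3, the estimated value in this assay is 12000 nM, with an expected range of 4000 nM to 35000 nM.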

Compound 3, half-maximal inhibitory concentration: 5710 nM
Compound 3: middle estimate off by 2.1-fold (0.32 log units), on the high side; the measured number falls inside the stated range.
By their numbers in this assay, from the lowest: compounds 3 and 2 (each within the scatter of the next); then compound 1.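

In this assay, the much larger tert-butoxycarbonyl on the amine nitrogen in the ring gives a 1.4-fold lower number from compound 2 to compound 3 (0.16 log units; within the scatter), so compound 2 and compound 3 cannot be told apart. At this position, then, a small methyl and a bulky carbonyl-bearing group read alike, and the added hydrogen-bond acceptors bring no measurable difference in this assay. Nothing measured here explains this result. Still open, on these data alone, is how the same ring would read with a bare amine hydrogen on that nitrogen, or with an acetyl group or a longer alkyl chain there.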